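The compounds below may be only part of what the source reports. "The series", "measured", "known", "first", "only" and "open" are said of these compounds alone.

Measured compounds:
Compound 1 `CCOC(=O)c1ccc(-c2nn(Cc3cccc(Cl)c3)c3ccccc23)cc1` — > 10000 nM
Compound 2 `CCOC(=O)c1ccc(-c2nn(-c3ccoc3)c3ccccc23)cc1` — > 10000 nM
Not yet measured: compound 3 `CCOC(=O)c1ccc(-c2nn(C(C)C)c3ccccc23)cc1`

In a functional assay on cells (Platelet, Homo sapiens) for inhibition (a higher number here means a weaker inhibitor, a lower number a stronger inhibitor), compound 1 gives only a limit, > 10000 nM, not a number. Compound 2 likewise gives only a limit in this assay, > 10000 nM. Within the data shown here, the one measured change, a step that the two limits leave unreadable from compound 1 to compound 2, therefore cannot be read for size or direction. Compound 3 differs from compound 1 at the same position: isopropyl in place of 3-chlorobenzyl on an aromatic nitrogen. Among the measured compounds shown here, no measured step bears on this change beyond the one unreadable step, and both values sit at the limit of > 10000 nM in this assay, at which 2 of the 2 values shown sit. For the measured compounds named here, no step of readable size can be expected in this assay, so the most plausible outcome is another limit. Compound 3 is estimated at 15000 nM, within 3000 nM to 60000 nM. This estimate means a step that the limit leaves unreadable from compound 1 to compound 3, expected to stay within the scatter.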

Compound 3, half-maximal inhibitory concentration: > 10000 nM
Compound 3: only a limit was reported (the forecaster's own chance of this, stated with the estimate: 75%); the middle value is on the limit's open side.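

Among these compounds, no step among compound 1, compound 2 and compound 3 can be read in this assay, because each gives only a limit, not a number: the limit of > 10000 nM in this assay, at which 3 of the 3 values shown sit. The compounds shown leave open whether any group on this aromatic nitrogen of the shared core gives a measurable inhibition value.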